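This account rests on a few compounds, and the source may have more. Where it says the series, first, only, none or still open, it means among the compounds named here.

Working notes on the anilide series sharing the trimethoxyphenyl and methoxy-hydroxybenzyl substituents on the amide nitrogen. In a functional assay on MGC-803 cells (Homo sapiens) for inhibition, read by MTT assay, with a stated time of 48 h (a higher number here means a weaker inhibitor, a lower number a stronger inhibitor), compound 1 `C=C(C)C(=O)N(Cc1ccc(OC)c(O)c1)c1cc(OC)c(OC)c(OC)c1` gives 390 nM. Compound 2 `CC/C=C/C(=O)N(Cc1ccc(OC)c(O)c1)c1cc(OC)c(OC)c(OC)c1` carries a but-1-en-1-yl group on the carbonyl carbon in place of the 1-methylethenyl group, and in this assay compound 2 gives 58 nM. The step of a 6.7-fold lower number from compound 1 to compound 2 (0.83 log units; beyond the scatter) is the only one measured so far, and on the two numbers available compound 2 stands at the lower end.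

Compound 3 `COc1ccc(CN(C(=O)CO)c2cc(OC)c(OC)c(OC)c2)cc1O` is the next member. Relative to compound 2 the change is hydroxymethyl in place of but-1-en-1-yl on a carbonyl carbon. The measured step from compound 1 to compound 2 bears on this only loosely, since it too alters the group on the carbonyl carbon, and it showed that a change there can move the result by a 6.7-fold lower number from compound 1 to compound 2 (0.83 log units; beyond the scatter). Nothing measured covers an acyl group with a hydroxymethyl group, so the direction rests on that single step alone.

The expectation for compound 3 in this assay is a step of a 6.9-fold higher number from compound 2 to compound 3 (0.84 log units; beyond the scatter), toward a higher number. Compound 3 is therefore estimated at 400 nM, with a plausible range from 100 nM to 2000 nM.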

Compound 3, half-maximal inhibitory concentration: 160 nM
Compound 3: middle estimate off by 2.5-fold (0.40 log units), on the high side, and the stated range covers the measured number.
By their numbers in this assay, from the lowest: compound 2; then compound 3; then compound 1.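

In this assay, hydroxymethyl in place of but-1-en-1-yl on a carbonyl carbon gives a 2.8-fold higher number from compound 2 to compound 3 (0.44 log units; beyond the scatter) and shows that this position also tolerates a group with no double bond, at some cost against compound 2. Hydroxymethyl in place of 1-methylethenyl gives a 2.4-fold lower number from compound 1 to compound 3 (0.39 log units; beyond the scatter) in the opposite direction, so the presence of a double bond alone does not set the order: compound 1 and compound 2 both carry one, yet their numbers lie on either side of the number for compound 3. No supporting measurement accompanies these steps to explain this order.

The step to compound 3 changes the heavy-atom count, the double bond and the hydrogen-bond donor and acceptor counts together, and the compounds shown do not separate these changes. Also open, on these data alone, is where a saturated chain such as propyl, or a group such as methoxymethyl or aminomethyl, would fall at this position relative to compound 2 and compound 3.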